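The compounds below may be only part of what the source reports. "The series", "measured", "known", "first", "only" and "open" are said of these compounds alone.

Measured so far in a functional assay on MCF7 cells (Homo sapiens) for cytotoxicity, read by XTT assay, with a stated time of 24 h; on this read-out lower numbers stand for stronger inhibition and higher numbers for weaker inhibition:
- compound 1 `CC(=O)Oc1cc(OC(C)=O)c2c(OC(C)=O)cc(C)c(Cl)c2c1OC(C)=O` gives 51100 nM
- compound 2 `COc1cc(C)cc2c1C(=O)C=CC2=O` gives 15300 nM
- compound 3 `COc1cc(C)c(Cl)c2c1C(=O)C=CC2=O` gives 20600 nM

Compound 1 stands highest of the three; its nearest number is that of compound 3, and compound 2 lies furthest. How the core of compound 1 differs from that of compound 3 is not broken down here.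

One change recurs. From compound 3 to compound 2 it is hydrogen in place of chloro on an aromatic carbon and gives a 1.3-fold lower number from compound 3 to compound 2 (0.13 log units; within the scatter). Compound 4 `CC(=O)Oc1cc(OC(C)=O)c2c(OC(C)=O)cc(C)cc2c1OC(C)=O` is still to be measured; from compound 1 it is hydrogen in place of chloro on an aromatic carbon. The surroundings differ: in one case the place is para to a methoxy group (2 heavy atoms), in the other para to an acetoxy group (4 heavy atoms), so this is the same kind of change, not the same.

Because compound 3 to compound 2 gave a 1.3-fold lower number from compound 3 to compound 2 (0.13 log units; within the scatter), the step expected for compound 4 is a 1.3-fold lower number from compound 1 to compound 4 (0.11 log units; within the scatter). In this assay compound 4 is estimated at 40000 nM, expected between 18000 nM and 90000 nM.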

Compound 4, half-maximal inhibitory concentration: 82000 nM
Beside the measured number, compound 4's estimate is 2.1-fold (0.31 log units) below it; the range from low to high includes it.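

In this assay, hydrogen in place of chloro on the core of compound 1 gives a 1.6-fold higher number from compound 1 to compound 4 (0.21 log units; within the scatter), a step within the scatter. Carried between the two cores, the change shows no difference that can be read: the same change on two cores in this assay, a 1.3-fold lower number (0.13 log units; within the scatter) from compound 3 to compound 2 and a 1.6-fold higher number (0.21 log units; within the scatter) from compound 1 to compound 4, 2.2-fold (0.33 log units) apart, within the scatter of two such steps. This shows that on both cores the exchange of chloro for hydrogen leaves the number within the scatter, but it does not fix a size or direction for the step, nor show that the two surroundings, a methoxy group and an acetoxy group, act alike.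

Only chloro and hydrogen appear at this place on an aromatic carbon. Going by these compounds, whether an amine, a carboxylic acid or a longer chain there would give a step beyond the scatter remains open.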